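A few compounds are considered here, and "the series" means these few. Any claim that something is new, unique, unknown or untested is made for them only; others in the source may bear on it.

Compound 1 `COc1c(-c2ccc(C(F)(F)F)cc2Cl)ccc2c1cnn2[C@@H](CC(C)C)c1ccc(C(=O)NCCC(=O)O)cc1`: 93%
Compound 2 `COc1c(-c2ccc(C(F)(F)F)cc2Cl)ccc2nn([C@@H](CC(C)C)c3ccc(C(=O)NCCC(=O)O)cc3)cc12`: 89%

In an ADME assay on microsomes from liver (Homo sapiens) for metabolic stability, with a stated time of 10 min, tested at 1 uM (on this read-out lower numbers stand for a less stable compound and higher numbers for a more stable compound), compound 2 gives 89% and compound 1 gives 93%, so the two numbers lie within the usual scatter of each other. The account now turns from compound 2 to compound 3 `COc1c(-c2ccc(C(F)(F)F)cc2Cl)ccc2nn([C@H](CC(C)C)c3ccc(C(=O)NCCC(=O)O)cc3)cc12`, which has not yet been measured. The structural difference is the two compounds have the same atoms and bonds and differ only in configuration as drawn: 1 of 1 stereo elements differ; a stereocentre at a saturated chain carbon is drawn S in compound 2 and R in compound 3. Going by the values given here, no measured pair shows what such a change of configuration does to this read-out, so the data offer no direct guide to its size. In this assay, no step beyond the scatter is expected, and no direction is firmly favoured. That expectation starts from compound 2 at 89%, with some allowance for a drop. The expected step is a number 3 percentage points lower from compound 2 to compound 3 (within the scatter). For compound 3 the estimated value is 86%, with an expected range from 70% to 97%.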

Compound 3, percent of the compound remaining: 116%
Compound 3: the middle estimate sits 30 percentage points below what was measured; the measured number lies above the stated range.
By their numbers in this assay, from the lowest: compounds 2 and 1 (each within the scatter of the next); then compound 3.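

Compound 2 and compound 3 show that this stereocentre at a saturated chain carbon matters for this assay: going from S to R gives a number 27 percentage points higher from compound 2 to compound 3 (beyond the scatter). Before this pair, no measured compounds isolated configuration, and the earlier numbers lay within the scatter of each other. The step can be assigned to the stereocentre alone because nothing else separates the pair, as shown by one fact: the fact that compounds 2 and 3 differ only in the configuration as drawn

This single pair does not show whether the same inversion would shift the read-out on the core of compound 1. It also leaves open whether the step would persist with an amine in place of the carboxylic acid, or with a longer chain at the stereocentre.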